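The compounds below may be only part of what the source reports. "The series", "measured", "known", "first", "only" and "open" are said of these compounds alone.

In a functional assay on MDA-N cells (Homo sapiens) for antiproliferative activity (on this read-out higher numbers stand for weaker inhibition of growth and lower numbers for stronger inhibition of growth), compound 1 `Cc1ccc2c(O)cc(-c3cccc(Cl)c3)nc2n1` gives > 100000 nM, which is a limit of the assay and not a number. Compound 3 `Cc1ccnc2nc(-c3cccc4ccccc34)cc(O)c12`, which carries a methyl on the ring carbon opposite the ring nitrogen, gives < 10 nM, also a limit. Among the measured compounds shown here, compound 2 `Oc1cc(-c2ccc3ccccc3c2)nc2ncccc12`, at 1660 nM, is therefore the only true number so far. Compound 4 `Cc1ccnc2nc(-c3ccc4ccccc4c3)cc(O)c12` differs from compound 2 by one change: methyl in place of hydrogen on an aromatic carbon, opposite the ring nitrogen. For the measured compounds named here, no measured pair isolates this change, so the expectation is only tentative: a moderate gain towards stronger inhibition of growth, well beyond the usual scatter. The expected step is a 5.5-fold lower number from compound 2 to compound 4 (0.74 log units; beyond the scatter). For compound 4 the estimated value is 300 nM, with a range of 30 nM to 3000 nM.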

Compound 4, concentration for 50% growth inhibition: 204 nM
Compound 4: the middle estimate sits 1.5-fold (0.17 log units) above what was measured; the measured number falls inside the stated range.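

In this assay, methyl in place of hydrogen on an aromatic carbon, opposite the ring nitrogen, gives an 8.1-fold lower number from compound 2 to compound 4 (0.91 log units; beyond the scatter). Among the compounds shown here, this is the first time a single change at this position can be sized, with true numbers at both ends. Compound 3 also carries this methyl, but its value is a limit and not a number: the limit of < 10 nM in this assay, at which 1 of the 4 values shown sits.

As far as these compounds go, whether an ethyl, a methoxy or an amine at this position would go further remains open. So does whether the methyl gives a similar step when the group on the rest of the core is different.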